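The compounds below may be only part of what the source reports. "The series", "measured", "known", "first", "only" and "open" are said of these compounds alone.

Three compounds built on one shared core have so far been examined in a functional assay on BGC-823 cells (Homo sapiens) for antiproliferative activity, read by MTT assay, tested at 5 uM; a higher number here means a stronger effect of the compound at the concentration tested, a lower number a weaker effect. Compound 1 `COc1ccc(OC)c(/C=N/NC(=O)c2cc(OC)c(OC)c(OC)c2)c1` gives 10.1% in this assay. Compound 2 `COc1cc(C(=O)N/N=C/c2ccccc2C(F)(F)F)cc(OC)c1OC` gives 35.6%. Compound 3 `COc1cc(C2=NN(C(C)=O)C(c3ccccc3C(F)(F)F)O2)cc(OC)c1OC` gives 34.8%, the second highest of the three numbers; the value of compound 2 lies within the usual scatter of that of compound 3, while the value of compound 1 lies beyond the scatter, below it. Compound 4 `COc1cc(C2=NN(C(C)=O)C(c3ccccc3F)O2)cc(OC)c1OC` has not yet been measured. It differs from compound 3 in one place: fluoro in place of trifluoromethyl on an aromatic carbon Cut one bond further out, the change reads 2-(trifluoromethyl)phenyl to 2-fluorophenyl, on an aromatic carbon of a six-membered aromatic ring of carbon only, ortho to a large group. No step between two measured compounds isolates this change, so the expectation rests on the numbers shown alone. Because compound 3 gives 34.8% and compound 2 gives 35.6%, a middling level seems attached to this core when a substituted phenyl is present. The expected step is small, most likely not beyond the scatter, with a slight lean downward: a number 6.8 percentage points lower from compound 3 to compound 4 (within the scatter). Compound 4 is estimated at 28%, within a range from 10% to 45%.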

Compound 4, a percentage reported as inhibition, at one concentration (the size of the read-out at that concentration, not a potency): 32.8%
Compound 4: middle estimate off by 4.8 percentage points, on the low side; low and high end bracket the measured number.
By their numbers in this assay, from the lowest: compound 1; then compounds 4, 3 and 2 (each within the scatter of the next).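

In this assay, fluoro in place of trifluoromethyl on an aromatic carbon, ortho to a large group, gives a number 2 percentage points lower from compound 3 to compound 4 (within the scatter). This is the first step among these compounds that isolates a single change at this position, and it shows that a group of one heavy atom and a group of four heavy atoms, both without hydrogen-bond donors or acceptors, leave the read-out within the scatter on this core. Nothing measured here bears on why the two groups read alike.

The compounds shown leave open whether the read-out would hold with a different kind of group on this aromatic carbon, such as an amine, a carboxylic acid or a longer alkyl chain, or with only hydrogen there. They also leave open whether the same exchange would read alike on the core of compound 2, and whether compound 3 and compound 4 would stay this close at other concentrations, given that the read-out reflects one concentration and is not a potency.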